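The source may hold more compounds than are shown below. What is called first, only, known or untested is meant among the compounds shown, and "the series" means these compounds.

Measured so far in a functional assay on HeLa S3 cells (Homo sapiens) for antiproliferative activity, read by XTT assay, with a stated time of 72 h; on this read-out higher numbers stand for weaker inhibition and lower numbers for stronger inhibition:
- compound 1 `CN(C)c1ncnc2c1c(-c1ccsc1)cn2[C@@H]1O[C@H](CO)[C@@H](O)[C@H]1O` gives > 15000 nM, a limit of the assay rather than a number
- compound 2 `COc1ncnc2c1c(-c1cccs1)cn2[C@@H]1O[C@H](CO)[C@@H](O)[C@H]1O` gives 1760 nM
- compound 3 `CSc1ncnc2c1c(-c1cccs1)cn2[C@@H]1O[C@H](CO)[C@@H](O)[C@H]1O` gives 1960 nM

Compound 3 holds the highest of the two numbers, with compound 2 nearest at a 1.1-fold higher number from compound 2 to compound 3 (0.05 log units; within the scatter). Compound 4 `CN(C)c1ncnc2c1c(-c1cccs1)cn2[C@@H]1O[C@H](CO)[C@@H](O)[C@H]1O` differs from compound 3 by dimethylamino in place of methylsulfanyl on an aromatic carbon. No measured step matches this change; the only step shown, the one from methoxy to methylsulfanyl, stayed within the scatter. Compound 1 carries the same dimethylamino group on a different thienyl isomer and reaches only a limit, (the limit of > 15000 nM in this assay, at which 1 of the 3 values shown sits). Compound 4 is therefore expected to weaken, by a 4.1-fold higher number from compound 3 to compound 4 (0.61 log units; beyond the scatter). The estimate for compound 4 in this assay is 8000 nM, between 2500 nM and 30000 nM.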

Compound 4, half-maximal inhibitory concentration: > 20000 nM
Compound 4: a limit, no number; the forecaster's own chance of this, stated with the estimate: 35%; middle value at least 2.5-fold (0.39 log units) away from the limit.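

Dimethylamino is the first group here to move the read-out beyond the scatter at this position, towards weaker inhibition, with an at least 10-fold higher number from compound 3 to compound 4 (1.00 log units; beyond the scatter) and an at least 11-fold higher number from compound 2 to compound 4 (1.05 log units; beyond the scatter). Compound 4 stands at a limit of the assay, not a number: the limit of > 20000 nM in this assay, at which 1 of the 4 values shown sits. The step between compound 1 and compound 4 cannot be read, as both carry limits.

Still open, from the compounds shown here alone, is how a free amino group or a methylamino group would read at this position. Also open, going by these compounds, is whether a longer chain on the oxygen, such as ethoxy, would stay close to compound 2.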